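The compounds below may be only part of what the source reports. "The series", "measured", "known", "first", "only" and "open" are said of these compounds alone.

Measured compounds:
Compound 1 `O=C(/C(=C\c1c[nH]c2ccc(Cl)cc12)SCc1ccc(F)cc1)c1ccc(Br)cc1`: 1000 nM
Compound 2 `Cc1ccc(/C=C(\C(=O)c2ccc(Cl)cc2)S(=O)(=O)Cc2ccc(F)cc2)s1`: 50000 nM
Compound 3 `Cc1ccc(CS(=O)(=O)/C(=C/c2cccc(Cl)c2Cl)C(=O)c2ccc(Cl)cc2)cc1`: 1000 nM

In a functional assay on DU-145 cells (Homo sapiens) for inhibition, read by trypan blue exclusion, with a stated time of 96 h (on this read-out lower numbers stand for stronger inhibition of growth and higher numbers for weaker inhibition of growth), compound 3 gives 1000 nM, level with compound 1 at 1000 nM. These two share the lowest of the three numbers. Compound 2 stands much higher at 50000 nM, a gap beyond the usual scatter.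

The next compound, compound 4 `Cc1ccc(CS(=O)(=O)/C(=C/c2c[nH]c3ccc(Br)cc23)C(=O)c2ccc(Cl)cc2)cc1`, keeps most of compound 3 but has 5-bromo-1H-indol-3-yl in place of 2,3-dichlorophenyl on a double-bonded chain carbon bound to a double-bonded chain carbon.

Within the data shown here, no two measured compounds differ in only one place, so no measured step shows directly what this swap does. The nearest clue is compound 1, which carries a group close to the entering one and gives 1000 nM. On that basis, no change beyond the scatter is expected in this assay, in either direction: the expected step is a 1.3-fold lower number from compound 3 to compound 4 (0.10 log units; within the scatter). For compound 4 the estimated value is 800 nM, with an expected range of 200 nM to 3000 nM.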

Compound 4, concentration for 50% growth inhibition: 10000 nM
The estimate for compound 4 lay 13-fold (1.10 log units) below the measured number, and the stated range ends below it.
By their numbers in this assay, from the lowest: compounds 1 and 3 (each within the scatter of the next); then compound 4; then compound 2.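

In this assay, the group on a double-bonded chain carbon bound to a double-bonded chain carbon turns out to matter: 5-bromo-1H-indol-3-yl in place of 2,3-dichlorophenyl gives a 10-fold higher number from compound 3 to compound 4 (1.00 log units; beyond the scatter). Among these compounds, this is the first change in one place alone in the set, so it is the first direct sign that growth inhibition on this core depends on the group at this position, and here the swap weakens it. Nothing available explains the loss, so the step stands as an observation only.

Still open, going by these compounds, is whether the loss follows the bromine or the indole rings themselves, which a 1H-indol-3-yl group without bromine or a plain phenyl at this place would help to separate. Also open, on these data alone, is how other groups, such as a pyridine ring, would fare here.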